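Ethylsulfonyl Analogue: Expected Stability in Human Liver Microsomes

The source may hold more compounds than are shown below. What is called first, only, known or untested is meant among the compounds shown, and "the series" means these compounds.

Three compounds have been measured in an ADME assay on microsomes from liver (Homo sapiens) for metabolic stability, with a stated time of 10 min; a lower number here means that less of the compound is left, a higher number that more of the compound is left:
compound 1 `O=C(NS(=O)(=O)c1ccccc1)c1ccc(Nc2nc(NC3(c4ccc(Cl)cc4)CC3)nc(OCC(F)(F)F)n2)cc1`, 100%
compound 2 `CC(C)C(=O)NCCS(=O)(=O)NC(=O)c1ccc(Nc2nc(NC3(c4ccc(Cl)cc4)CC3)nc(OCC(F)(F)F)n2)cc1`, 86%
compound 3 `CC(C)S(=O)(=O)NC(=O)c1ccc(Nc2nc(NC3(c4ccc(Cl)cc4)CC3)nc(OCC(F)(F)F)n2)cc1`, 100%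

Compound 1 stands level with compound 3 at the digits shown, the two together the highest of the three numbers, while compound 2 lies lower: a number 14 percentage points lower from compound 1 to compound 2 (beyond the scatter). Compound 4 `CCS(=O)(=O)NC(=O)c1ccc(Nc2nc(NC3(c4ccc(Cl)cc4)CC3)nc(OCC(F)(F)F)n2)cc1` differs from compound 1 in one place: ethyl in place of phenyl on a sulfonyl sulfur. The step that bears most on this is the exchange of phenyl for isopropyl on the same sulfonyl sulfur, which gave no change at the digits printed from compound 1 to compound 3 (within the scatter); only the longer 2-((isopropylcarbonyl)amino)ethyl moved the number, by a number 14 percentage points lower from compound 1 to compound 2 (beyond the scatter). Compound 4, carrying ethyl, is therefore expected to stay within the scatter of compound 1: a number 4 percentage points lower from compound 1 to compound 4 (within the scatter). Compound 4 is estimated at 96%, between 82% and 100%.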

Compound 4, percent of the compound remaining: 100%
Beside the measured number, compound 4's estimate is 4 percentage points below it; measured number inside the range.
By their numbers in this assay, from the lowest: compound 2; then compounds 1, 3 and 4 (each within the scatter of the next).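

With ethyl on the sulfonyl sulfur, this assay shows no change at the digits printed from compound 1 to compound 4 (within the scatter) and no change at the digits printed from compound 3 to compound 4 (within the scatter) when phenyl gives way to ethyl and when the methyl of isopropyl gives way to hydrogen, so neither change moves the read-out. Replacing (isopropylcarbonyl)amino with hydrogen on the chain does give a step, a number 14 percentage points higher from compound 2 to compound 4 (beyond the scatter) for that exchange. No measurement at hand explains these steps. From the compounds shown here alone, it remains open whether an amine or a carboxylic acid on the ethyl chain, or a longer plain carbon chain, would lower the number as (isopropylcarbonyl)amino does.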